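A few compounds are considered here, and "the series" means these few. Any claim that something is new, unique, unknown or untested is made for them only; others in the source may bear on it.

Measured so far in a functional assay on MCF7 cells (Homo sapiens) for antiproliferative activity, read by MTT assay, with a stated time of 48 h; a higher number here means a weaker inhibitor, a lower number a stronger inhibitor:

- compound 1 `Clc1ccc(-c2nn(-c3ccccc3)cc2-c2nc3ccccc3[nH]2)cc1`: 3030 nM
- compound 2 `FC(F)(F)c1ccc2[nH]c(-c3cn(-c4ccccc4)nc3-c3ccc(Cl)cc3)nc2c1`: 4210 nM
- compound 3 `Cc1ccc2[nH]c(-c3cn(-c4ccccc4)nc3-c3ccc(Cl)cc3)nc2c1`: 8230 nM

Compound 3 has the value 8230 nM. Two steps place it: a 2.0-fold higher number from compound 2 to compound 3 (0.29 log units; within the scatter) lies within the scatter, while a 2.7-fold higher number from compound 1 to compound 3 (0.43 log units; beyond the scatter) lies beyond it, though only modestly.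

Compound 4 `O=C(OCc1ccccc1)c1ccc2[nH]c(-c3cn(-c4ccccc4)nc3-c3ccc(Cl)cc3)nc2c1` has benzyloxycarbonyl in place of methyl on an aromatic carbon.

The closest guides are the swaps of hydrogen for a small group: a 1.4-fold higher number from compound 1 to compound 2 (0.14 log units; within the scatter) for trifluoromethyl and a 2.7-fold higher number from compound 1 to compound 3 (0.43 log units; beyond the scatter) for methyl. Both are small. For the measured compounds named here, no measured compound carries benzyloxycarbonyl, so they guide only loosely, and no step beyond the scatter is expected. The estimated change is a 1.6-fold lower number from compound 3 to compound 4 (0.22 log units; within the scatter). For compound 4 the estimated value is 5000 nM, with an expected range from 1500 nM to 15000 nM.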

Compound 4, half-maximal inhibitory concentration: 13900 nM
Estimate against measurement, compound 4: 2.8-fold (0.44 log units) below; low and high end bracket the measured number.
By their numbers in this assay, from the lowest: compounds 1, 2, 3 and 4 (each within the scatter of the next, the first and the last beyond it).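

In this assay this aromatic carbon accepts a far larger group, benzyloxycarbonyl with its extra aromatic ring, without a loss beyond the scatter against methyl: the step of a 1.7-fold higher number from compound 3 to compound 4 (0.23 log units; within the scatter) shows that. Against the other two compounds the change does go beyond the scatter, with a 3.3-fold higher number from compound 2 to compound 4 (0.52 log units; beyond the scatter) from trifluoromethyl and a 4.6-fold higher number from compound 1 to compound 4 (0.66 log units; beyond the scatter) from hydrogen, both modest. No measurement here accounts for these steps.

Still open, from the compounds shown here alone, is whether a carboxylic acid or an amine on this carbon would give a lower number, and whether the benzyl part or the carbonyl drives the change.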